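Alpha-substituent on the ester carbon of the N-oxyphthalimide series

The source may hold more compounds than are shown below. What is called first, only, known or untested is meant among the compounds shown, and "the series" means these compounds.

Compound 3 `CCOC(=O)C(C)ON1C(=O)c2ccccc2C1=O` is the reference point. In a functional assay on the whole organism for inhibition, with Lepidium sativum as the target, tested at 1 ppm (a lower number here means less inhibition of growth, a higher number more inhibition of growth at the concentration tested), compound 3 gives 68%, the highest of the three numbers recorded. Compound 1 `CCCOC(=O)C(C)ON1C(=O)c2ccccc2C1=O` gives 64% in this assay, and a number 4 percentage points higher from compound 1 to compound 3 (within the scatter). Compound 2 `CCOC(=O)C(Cc1ccccc1)ON1C(=O)c2ccccc2C1=O` gives 0%, and a number 68 percentage points higher from compound 2 to compound 3 (beyond the scatter).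

Compound 4 `CCOC(=O)C(CC)ON1C(=O)c2ccccc2C1=O` has not yet been measured in this assay. Its change from compound 3 is methyl in place of hydrogen on a saturated chain carbon, two bonds along the chain from a carbonyl carbon and an oxygen on an unsaturated carbon. Going by the values given here, the step that bears on it is the one from compound 2 to compound 3, which sits on the same saturated chain carbon: there, removing phenyl in favour of hydrogen raised inhibition by a large amount beyond the scatter. The step from compound 1 to compound 3 concerns the ester side and was within the scatter, so it is not informative for this position. Going in the opposite direction with a smaller group, methyl rather than phenyl, a drop is expected for compound 4, though its size cannot be read from a single pair. The expected step is a number 28 percentage points lower from compound 3 to compound 4 (beyond the scatter), a decrease beyond the scatter. Compound 4 is estimated at 40%, with a range from 10% to 65%.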

Compound 4, percent growth inhibition at one concentration: 0%
Compound 4: the middle estimate sits 40 percentage points above what was measured; the measured number lies below the stated range.
By their numbers in this assay, from the lowest: compounds 2 and 4 (each within the scatter of the next); then compounds 1 and 3 (each within the scatter of the next).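

With a number 68 percentage points lower from compound 3 to compound 4 (beyond the scatter) in this assay as the read-out, a single added methyl on the saturated chain carbon, two bonds along the chain from a carbonyl carbon and an oxygen on an unsaturated carbon, is enough to remove all the recorded inhibition, so the loss at this position is not confined to phenyl. With no change at the digits printed from compound 2 to compound 4 (within the scatter) as the second reading, methyl and phenyl in this place cannot be told apart at the one concentration tested, and the series now drops as soon as the methyl of compound 3 becomes ethyl. No measurement on hand explains why this position responds so sharply.

Still open, on these data alone, is whether hydrogen, fluorine or a hydroxyl group in place of the methyl of compound 3 would keep the inhibition, which would show whether that methyl is itself needed or merely permitted. Also open, as far as these compounds go, is whether compound 2 and compound 4, which share the same reading here, would separate at a higher concentration, and whether a propyl ester, as in compound 1, would change the picture at this position.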